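Swapping benzyl for naphthalen-2-yl at a stability limit

The source may report more compounds than this note shows. Statements on the series, on what has been measured and on what is new or still open speak of the compounds shown alone.

Three compounds share one core and differ only in the group on a carbonyl carbon: compound 1 `COc1ccc(-c2c(C)nc3c(N4CC[C@@H](NC(=O)c5ccccc5)C4)cc(C)nn23)cc1OC`, compound 2 `CCCCCC(=O)N[C@@H]1CCN(c2cc(C)nn3c(-c4ccc(OC)c(OC)c4)c(C)nc23)C1` and compound 3 `COc1ccc(-c2c(C)nc3c(N4CC[C@@H](NC(=O)OCc5ccccc5)C4)cc(C)nn23)cc1OC`. All three were tested in an ADME assay on microsomes from liver (Mus musculus) for metabolic stability, read by LC-MS, with NADPH named in the record, with a stated time of 60 min, tested at 1 uM, in the absence of a further agent; a lower number here means that less of the compound is left, a higher number that more of the compound is left. Compound 1 gives > 95%, which is a limit and not a number. Compound 2 gives > 95%, again a limit. Compound 3 gives > 95%, also a limit. Within the data shown here, the series so far therefore stands at the limit of > 95% in this assay, at which 3 of the 3 values shown sit.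

In compound 4 `COc1ccc(-c2c(C)nc3c(N4CC[C@@H](NC(=O)Oc5ccc6ccccc6c5)C4)cc(C)nn23)cc1OC`, naphthalen-2-yl takes the place of benzyl on an oxygen next to a carbonyl group: naphthalen-2-yl in place of benzyl on an oxygen next to a carbonyl group. The measured changes at this part of the molecule are a step that the two limits leave unreadable from compound 1 to compound 3 and a step that the two limits leave unreadable from compound 2 to compound 3, along with a step that the two limits leave unreadable from compound 1 to compound 2. Among the measured compounds shown here, none of them has a size that can be carried over, and no measured compound holds naphthalen-2-yl. The expectation thus rests on one fact: the three different groups all gave the same limit in this assay. Any visible change is expected to be a fall, and it may stay within the usual scatter. The expected move is a number at least 7 percentage points lower from compound 3 to compound 4 (that floor lies within the scatter). For compound 4 the estimate is 88%, with an expected range from 65% to 100%.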

Compound 4, percent of the compound remaining: > 95%
Compound 4: a limit, no number; the forecaster's own chance of this, stated with the estimate: 45%; at least 7 percentage points between middle value and limit.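

Compound 4 ends at a limit in this assay, just as compound 1, compound 2 and compound 3 do, so no step among these compounds can be read. The position of the series is unchanged: the limit of > 95% in this assay, at which 4 of the 4 values shown sit.

The compounds shown leave open whether phenyl, pentyl, benzyloxy and (naphthalen-2-yl)oxy differ at all in this assay.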